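This account rests on a few compounds, and the source may have more. Where it says the series, first, only, none or still open, it means among the compounds named here.

Compound 3 `O=c1c(S(=O)(=O)c2ccc(F)cc2F)cc2cnc(Nc3ccc4[nH]ccc4c3)nc2n1CC1CC1` gives 1000 nM in a functional assay on K562 cells (Homo sapiens) for inhibition, read by trypan blue exclusion, with a stated time of 72 h (a higher number here means a weaker inhibitor, a lower number a stronger inhibitor), the lowest of the three numbers in hand. Compound 1 `Cn1c(=O)c(S(=O)(=O)c2ccc(F)cc2F)cc2cnc(Nc3ccc4cc[nH]c4c3)nc21` gives 5000 nM in this assay, and compound 2 `Cn1c(=O)c(S(=O)(=O)c2ccc(F)cc2F)cc2cnc(Nc3ccc4[nH]ncc4c3)nc21` gives 50000 nM. Going by the values given here, the one measured step, a 10-fold higher number from compound 1 to compound 2 (1.00 log units; beyond the scatter), concerns a group placed on a nitrogen on an aromatic ring and says nothing about the chain carried by the ring nitrogen of the shared core. Compound 4 `COC(=O)Cn1c(=O)c(S(=O)(=O)c2ccc(F)cc2F)cc2cnc(Nc3ccc4[nH]ccc4c3)nc21` differs from compound 3 by methoxycarbonyl in place of cyclopropyl on a saturated chain carbon bound to an aromatic nitrogen. Among the compounds with values here, no measured pair isolates this change: compound 1 and compound 3 differ in more than one place, so their two values show only that compound 3 sits lower. Within the data shown here, with no precedent for the chain, the step expected in this assay is small, a 2.0-fold higher number from compound 3 to compound 4 (0.30 log units; within the scatter), carrying wide uncertainty in either direction. Compound 4 is therefore estimated at 2000 nM, with a range from 500 nM to 8000 nM.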

Compound 4, half-maximal inhibitory concentration: 5000 nM
The estimate for compound 4 lay 2.5-fold (0.40 log units) below the measured number; the range from low to high includes it.
By their numbers in this assay, from the lowest: compound 3; then compounds 1 and 4 (each within the scatter of the next); then compound 2.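

Going by these compounds alone, this is the first measured step for the group on a saturated chain carbon bound to an aromatic nitrogen: in this assay, methoxycarbonyl in place of cyclopropyl gives a 5.0-fold higher number from compound 3 to compound 4 (0.70 log units; beyond the scatter). The result shows that this position is not indifferent to what it carries, since replacing a three-membered carbon ring, which has no hydrogen-bond acceptors, with an open group that has two goes with a weaker inhibitor in compound 4 than in compound 3. Nothing at hand explains this step.

Within the data shown here, the single step cannot separate the loss of the cyclopropyl ring from the arrival of the methoxycarbonyl group. From the compounds shown here alone, what a longer carbon chain, a carboxylic acid or an amine would give at this place remains open.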